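Aryl variation at the saturated ring carbon: compound 4

The source may hold more compounds than are shown below. What is called first, only, known or untested is meant among the compounds shown, and "the series" means these compounds.

The three measured compounds share one core and differ only in the group on the saturated ring carbon. Compound 1 `Cc1cc(O)c(C2=NN(c3ccc(S(N)(=O)=O)cc3)C(c3ccccc3Cl)C2)cc1Cl` carries a 2-chlorophenyl there and in a functional assay on HOP-92 cells (Homo sapiens) for antiproliferative activity, with a stated time of 48 h (a lower number here means a stronger inhibitor of growth, a higher number a weaker inhibitor of growth), compound 1 gives 1940 nM. Compound 2 `Cc1cc(O)c(C2=NN(c3ccc(S(N)(=O)=O)cc3)C(/C=C/c3ccccc3)C2)cc1Cl` carries a 2-phenylethenyl, and in this assay compound 2 gives 2360 nM. Compound 3 `COc1ccc(C2CC(c3cc(Cl)c(C)cc3O)=NN2c2ccc(S(N)(=O)=O)cc2)cc1OC` carries a 3,4-dimethoxyphenyl, and in this assay compound 3 gives 1810 nM. Compound 3 stands together with the other two: the steps of a 1.1-fold lower number from compound 1 to compound 3 (0.03 log units; within the scatter) and a 1.3-fold lower number from compound 2 to compound 3 (0.12 log units; within the scatter) are within the scatter, as is a 1.2-fold higher number from compound 1 to compound 2 (0.09 log units; within the scatter).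

Compound 4 `COc1ccc(C2CC(c3cc(Cl)c(C)cc3O)=NN2c2ccc(S(N)(=O)=O)cc2)c(OC)c1OC` differs from compound 3 by methoxy in place of hydrogen on an aromatic carbon. Going by the values given here, no measured step adds a methoxy to a hydrogen on this ring; the three measured steps exchange the whole group on the saturated ring carbon, and each of them stays within the scatter. On that basis the expected step of a 1.0-fold higher number from compound 3 to compound 4 (0.02 log units; within the scatter) is none beyond the scatter. Compound 4 is therefore estimated at 1900 nM in this assay, with a range from 900 nM to 4000 nM.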

Compound 4, concentration for 50% growth inhibition: 2140 nM
Compound 4: middle estimate off by 1.1-fold (0.05 log units), on the low side; the measured number falls inside the stated range.
By their numbers in this assay, from the lowest: compounds 3, 1, 4 and 2 (each within the scatter of the next).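

Methoxy in place of hydrogen, ortho to a large group and ortho to a methoxy group, is the first change here made within an aryl group rather than by exchanging the whole group, and in this assay the step is a 1.2-fold higher number from compound 3 to compound 4 (0.07 log units; within the scatter) and stays within the scatter. The resulting 2,3,4-trimethoxyphenyl also stays within the scatter of the other two groups on the saturated ring carbon, with a 1.1-fold lower number from compound 2 to compound 4 (0.04 log units; within the scatter) and a 1.1-fold higher number from compound 1 to compound 4 (0.04 log units; within the scatter) as its steps. No measurement bears on why these numbers stay so close.

Going by these compounds, it remains open whether an aryl group carrying an amine or a carboxylic acid, or a longer alkyl chain, at this carbon would move the number beyond the scatter. Also open, on these data alone, is whether a change elsewhere on the shared core would separate these compounds.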